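A few compounds are considered here, and "the series" means these few. Any claim that something is new, unique, unknown or untested is made for them only; others in the source may bear on it.

Of the compounds shown here, three built on one shared core have been measured in a functional assay on T47D cells (Homo sapiens) for cytotoxicity, read by CCK-8 assay and cell counting, with a stated time of 2 days; on this read-out lower numbers stand for stronger inhibition and higher numbers for weaker inhibition. Compound 2 `Oc1cccc(-c2cc(-c3ccccc3)nc(-c3ccc(Cl)cc3)c2)c1` gives 11300 nM. Compound 1 `Oc1cccc(-c2cc(-c3ccc(Cl)cc3)nc(-c3ccsc3)c2)c1` gives 11500 nM, so the change thiophen-3-yl in place of phenyl on an aromatic carbon produced a 1.0-fold higher number from compound 2 to compound 1 (0.01 log units; within the scatter). Compound 3 `Oc1cccc(-c2cc(-c3ccccc3)nc(-c3ccccc3Cl)c2)c1` gives 2920 nM; its core differs from that of compound 2 by 2-chlorophenyl in place of 4-chlorophenyl on an aromatic carbon, and that change produced a 3.9-fold lower number from compound 2 to compound 3 (0.59 log units; beyond the scatter). Compound 4 `Oc1cccc(-c2cc(-c3ccsc3)nc(-c3ccccc3Cl)c2)c1` has not yet been measured. It differs from compound 3 by thiophen-3-yl in place of phenyl on an aromatic carbon, the same kind of change as from compound 2 to compound 1, though there the place was meta to a 4-chlorophenyl group, while here it is meta to a 2-chlorophenyl group. Because a 1.0-fold higher number from compound 2 to compound 1 (0.01 log units; within the scatter) stayed within the scatter, the step for compound 4 is expected to be a 1.0-fold higher number from compound 3 to compound 4 (0.01 log units; within the scatter). Compound 4 is estimated at 3000 nM, between 1400 nM and 7000 nM.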

Compound 4, half-maximal inhibitory concentration: 2440 nM
Compound 4: middle estimate off by 1.2-fold (0.09 log units), on the high side; measured number inside the range.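

In this assay, putting thiophen-3-yl in place of phenyl gives a 1.2-fold lower number from compound 3 to compound 4 (0.08 log units; within the scatter), so this swap leaves the number within the scatter on both cores: the same change on two cores in this assay, a 1.0-fold higher number (0.01 log units; within the scatter) from compound 2 to compound 1 and a 1.2-fold lower number (0.08 log units; within the scatter) from compound 3 to compound 4, 1.2-fold (0.09 log units) apart, within the scatter of two such steps. Putting 2-chlorophenyl in place of 4-chlorophenyl gives a 4.7-fold lower number from compound 1 to compound 4 (0.67 log units; beyond the scatter), and this lower number is seen on both cores: the same change on two cores in this assay, a 3.9-fold lower number (0.59 log units; beyond the scatter) from compound 2 to compound 3 and a 4.7-fold lower number (0.67 log units; beyond the scatter) from compound 1 to compound 4, 1.2-fold (0.09 log units) apart, within the scatter of two such steps. So each change behaved alike on the two cores here, but these four compounds do not show that it would carry over to other cores or other cell types.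

On these data alone, all four compounds carry the 3-hydroxyphenyl group, so what a methoxy group or an amine would do in place of its hydroxyl stays open. Also open, as far as these compounds go, is whether a carboxylic acid on the aromatic rings would alter the picture.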